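The source may report more compounds than this note shows. Statements on the series, on what has been measured and on what is new or still open speak of the compounds shown alone.

The series is followed in a functional assay on HCT-116 cells (Homo sapiens) for antiproliferative activity, read by MTT assay, with a stated time of 72 h; on this read-out higher numbers stand for weaker inhibition and lower numbers for stronger inhibition. Compound 1 `C=C1CN/C(=N/c2ccccc2)S1` in this assay gives > 100000 nM, which is a limit of the assay and not a number. Compound 2 `COc1ccc(/C=C2\S/C(=N\c3ccccc3)N(C)C2=O)cc1` in this assay gives > 100000 nM, again a limit rather than a measured number. For the measured compounds named here, compound 2 therefore stands at the limit of > 100000 nM in this assay, at which 2 of the 3 values shown sit, where most of the values so far sit. Going by the values given here, compound 3 `COc1ccc(/C=C2/CN(C)/C(=N/c3ccc(C(C)(C)C)cc3)S2)cc1` has a core that is not the shared core of the other compounds; in this assay compound 3 gives 25900 nM, the only numerical value in the set. Among the compounds with values here, no step between measured compounds that differ in one place is available, so the size of any single change is not yet known. Compound 4 `COc1ccc(/C=C2\S/C(=N\c3ccc(C)c(Cl)c3)N(C)C2=O)cc1` differs from compound 2 by 3-chloro-4-methylphenyl in place of phenyl on a double-bonded nitrogen. A step of an at least 2.0-fold lower number from compound 2 to compound 4 (0.30 log units; that floor lies within the scatter) is expected, towards stronger inhibition and somewhat beyond the scatter, since compound 3 with a larger substituted aryl on its double-bonded nitrogen gives 25900 nM. Compound 4 is expected to give 50000 nM, within 15000 nM to 200000 nM, with a fair chance that only a limit is reported again.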

Compound 4, half-maximal inhibitory concentration: 14100 nM
Compound 4: the middle estimate sits 3.5-fold (0.55 log units) above what was measured; the whole stated range lies above it.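

In this assay, for the compounds shown here, the position on the double-bonded nitrogen turns out to respond to substitution: 3-chloro-4-methylphenyl in place of phenyl gives an at least 7.0-fold lower number from compound 2 to compound 4 (0.85 log units; beyond the scatter), the only single-place step so far. Compound 4 gives 14100 nM, a measured number on the core of compound 2. Compound 2 is held only as a limit and not a number, so the step has a floor and no exact size: the limit of > 100000 nM in this assay, at which 2 of the 4 values shown sit.

The compounds shown leave open whether the chlorine or the methyl accounts for the step, and whether an amine or a carboxylic acid on the same aryl ring would give a similar result. They also leave open whether the same exchange would carry over to the core of compound 3.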